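Removing the aryl group from a pyridine alkyne acid

The compounds below may be only part of what the source reports. "The series", "measured", "known", "first", "only" and "open" are said of these compounds alone.

Compound 1, `COc1nccc(C#Cc2ccc(CCC(=O)O)cc2)n1`: in an in vitro functional assay on 1321-N1 cells for agonist activity at Free fatty acid receptor 1 (Homo sapiens), read by fluorescence, spectrophotometry and calcium flux (on this read-out higher numbers stand for an effect only at larger amounts of compound and lower numbers for an effect already at smaller amounts), compound 1 gives 9550 nM.
Compound 2, `Cc1ccccc1-c1cc(C#Cc2ccc(CCC(=O)O)cc2)ccn1`: in this assay compound 2 gives 1070 nM.
Compound 3, `O=C(O)CCc1ccc(C#Cc2ccc(Cl)nc2)cc1`: in this assay compound 3 gives 708 nM.

Compound 2 holds the second highest of the three numbers. Compound 3 lies within the scatter of it, so no order can be read between those two; compound 1 lies beyond the scatter, at a clearly higher number. Compound 4, `O=C(O)CCc1ccc(C#Cc2ccncc2)cc1`, differs from compound 2 in one place: hydrogen in place of 2-methylphenyl on an aromatic carbon. Among the compounds with values here, no measured pair shows this change on its own, so its effect is open. Both smaller compounds sit at or above compound 2, compound 1 with 9550 nM and compound 3 with 708 nM, which makes a rise in number the more likely outcome. In this assay the step of a 4.7-fold higher number from compound 2 to compound 4 (0.67 log units; beyond the scatter) is expected to go toward a higher number, beyond the scatter. Compound 4 is expected near 5000 nM, within 1500 nM to 20000 nM.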

Compound 4, half-maximal effective concentration: 4070 nM
The estimate for compound 4 lay 1.2-fold (0.09 log units) above the measured number; the measured number falls inside the stated range.
By their numbers in this assay, from the lowest: compounds 3 and 2 (each within the scatter of the next); then compound 4; then compound 1.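

Within the data shown here, compounds 2 and 4 give the first direct reading of this position. On the aromatic carbon next to the ring nitrogen, hydrogen in place of 2-methylphenyl gives in this assay a 3.8-fold higher number from compound 2 to compound 4 (0.58 log units; beyond the scatter) and so shows that, on this core, the aryl group lets the effect appear at smaller amounts of compound. No measurement here explains why.

As far as these compounds go, it remains open whether the whole 2-methylphenyl group is needed. A plain phenyl ring, a methyl group or an amine on this carbon would show how much of the step each part carries.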